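The compounds below may be only part of what the source reports. "The series", "measured", "known", "first", "only" and "open" are said of these compounds alone.

Measured so far in an assay on cells for binding affinity to Cyclin-C/Cyclin-dependent kinase 19 (Homo sapiens), read by LanthaScreen; on this read-out higher numbers stand for weaker inhibition and lower numbers for stronger inhibition:
Compound 1 `Cn1ncc2cc(-c3cnc4[nH]ncc4c3N3CCC4(CCNC4=O)CC3)ccc21` gives 214 nM
Compound 2 `O=C1NCCC12CCN(c1c(-c3ccc4scnc4c3)cnc3[nH]ccc13)CC2` gives 14 nM

Compound 2 holds the lower of these two numbers in this assay, and compound 1 sits at a number higher by an amount well beyond the ordinary scatter of repeated measurements. The two differ in several places at once, so no single-point step can be read from them.

Compound 3 `O=C1NCCC12CCN(c1c(-c3ccc4ncsc4c3)cnc3[nH]ccc13)CC2` is the next compound and has not yet been measured. It keeps everything of compound 2 and changes only how the attached group is joined: 1,3-benzothiazol-6-yl in place of 1,3-benzothiazol-5-yl on an aromatic carbon. No measured step of this kind is available among these compounds, so only a small shift is expected, in either direction, and quite possibly none beyond the scatter. Compound 3 is therefore estimated at 25 nM in this assay, with a range from 7 nM to 90 nM. That estimate corresponds to an expected step of a 1.8-fold higher number from compound 2 to compound 3 (0.25 log units; within the scatter).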

Compound 3, half-maximal inhibitory concentration: 80 nM
Beside the measured number, compound 3's estimate is 3.2-fold (0.51 log units) below it; low and high end bracket the measured number.
By their numbers in this assay, from the lowest: compound 2; then compound 3; then compound 1.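

Joining the same group differently is enough to matter in this assay: 1,3-benzothiazol-6-yl in place of 1,3-benzothiazol-5-yl gives a 5.7-fold higher number from compound 2 to compound 3 (0.76 log units; beyond the scatter) on an aromatic carbon of the shared core. The two groups have identical counts of heavy atoms, rings, hydrogen-bond donors and acceptors, so this position responds to the point of attachment, not only to which atoms are present, something the earlier pair could not show. No measurement available here bears on why the number rises.

For the compounds shown here, with only this one change readable at this position, it remains open how a different group there, such as a phenyl ring carrying an amine or a carboxylic acid, would compare. Compound 1 differs from compound 2 in several places, so its higher number cannot be assigned to any single change.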